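Methyl Added to the Chlorophenylsulfonyl Amide of Compound 2

The compounds below may be only part of what the source reports. "The series", "measured", "known", "first", "only" and "open" are said of these compounds alone.

Compound 2 `COc1cc(C(=O)NS(=O)(=O)c2ccccc2Cl)ccc1Cn1ccc2ccc(NC(=O)CC3CCCC3)cc21` stands highest of the three measured compounds in a functional assay (trachea) for antagonist activity, with Cavia porcellus as the target; a lower number here means a less potent compound, a higher number a more potent compound, by a factor of ten per unit of this negative logarithm: compound 2 gives 9.8. Compound 1 `CCCCC(CC)C(=O)Nc1ccc2ccn(Cc3ccc(C(=O)NS(=O)(=O)c4ccccc4)cc3OC)c2c1` comes nearest, and in this assay compound 1 gives 8.6. Compound 3 `CCCCC(CC)C(=O)Nc1ccc2ccn(Cc3ccc(C(=O)NS(=O)(=O)c4ccccc4)cc3)c2c1` lies furthest away; in this assay compound 3 gives 6.8. Among the measured compounds shown here, the only single-point step among them, a number 1.80 log units lower from compound 1 to compound 3 (beyond the scatter), concerns the benzyl ring and not the sulfonyl aryl group.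

Compound 4 `COc1cc(C(=O)NS(=O)(=O)c2c(C)cccc2Cl)ccc1Cn1ccc2ccc(NC(=O)CC3CCCC3)cc21` differs from compound 2 by methyl in place of hydrogen on an aromatic carbon. For the measured compounds named here, none of the measured steps touches this part of the molecule, so the data give no direct guide to the size or direction of the change. Going by the values given here, with compound 2 already at the top of the measured range and no step bearing on the new position, the expectation for compound 4 is a number close to that of compound 2: compound 4 is estimated at 9.8, within 9 to 10.4, which means an expected step of no change at the digits printed from compound 2 to compound 4 (within the scatter).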

Compound 4, negative logarithm of the antagonist equilibrium constant: 8.8
Beside the measured number, compound 4's estimate is 1.00 log units above it, and the stated range ends above it.
By their numbers in this assay, from the lowest: compound 3; then compounds 1 and 4 (each within the scatter of the next); then compound 2.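

In this assay, among the compounds shown here, the change to the 2-chloro-6-methylphenyl group gives the first direct reading on the sulfonyl aryl ring: a number 1.00 log units lower from compound 2 to compound 4 (beyond the scatter). This ring therefore responds in this assay, since one methyl on an aromatic carbon, ortho to a large group and meta to a chloro group, moves the number down beyond the scatter. Nothing shown accounts for the drop.

As far as these compounds go, it remains open whether the loss is specific to methyl or would also follow another group at this place, such as fluoro, ethyl or an amine. The compounds also leave open whether methyl here would bring a step of similar size on a sulfonyl phenyl ring without the chloro group.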